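The compounds below may be only part of what the source reports. "The series", "measured", "known", "first", "only" and "open" are said of these compounds alone.

Series notes, permeability. Compound 2 `CC1(C)CO[C@@H]1CN([C@H](CCC(F)(F)F)C(N)=O)S(=O)(=O)c1ccc(Cl)cc1` gives 22.3 10^-6 cm/s in an ADME assay on MDCKII-LE cells (Canis lupus familiaris) for permeability, read by transwell migration, in the apical to basolateral direction; on this read-out higher numbers stand for higher permeability and lower numbers for lower permeability. Compound 1 `CC1(C)C[C@H](CN([C@H](CCC(F)(F)F)C(N)=O)S(=O)(=O)c2ccc(Cl)cc2)O1` gives 18.1 10^-6 cm/s and compound 3 `NC(=O)[C@@H](CCC(F)(F)F)N(C[C@H]1CCCCO1)S(=O)(=O)c1ccc(Cl)cc1` gives 13.4 10^-6 cm/s, so compound 2 stands highest of the three numbers, though a 1.2-fold higher number from compound 1 to compound 2 (0.09 log units; within the scatter) and a 1.7-fold lower number from compound 2 to compound 3 (0.22 log units; within the scatter) both fall within the scatter, as does a 1.4-fold lower number from compound 1 to compound 3 (0.13 log units; within the scatter). Compound 4 `NC(=O)[C@@H](CCC(F)(F)F)N(C[C@H]1CCCOC1)S(=O)(=O)c1ccc(Cl)cc1` is not yet measured and differs from compound 2 by oxan-3-yl in place of 3,3-dimethyloxetan-2-yl on a saturated chain carbon bound to a sulfonamide nitrogen. Both earlier steps bear on this change, one swapping the two dimethyloxetanyl groups and one replacing an oxetanyl group with oxan-2-yl, and neither moved the read-out beyond the scatter. The expected step is therefore a 1.4-fold lower number from compound 2 to compound 4 (0.14 log units; within the scatter), nothing beyond the scatter. Compound 4 is estimated at 16 10^-6 cm/s, within 9 10^-6 cm/s to 28 10^-6 cm/s.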

Compound 4, apparent permeability: 18.2 10^-6 cm/s
Estimate against measurement, compound 4: 1.1-fold (0.06 log units) below; the range from low to high includes it.
By their numbers in this assay, from the lowest: compounds 3, 1, 4 and 2 (each within the scatter of the next).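

At this place, on a saturated chain carbon bound to a sulfonamide nitrogen, oxan-3-yl joins the other three groups within the scatter in this assay: a 1.2-fold lower number from compound 2 to compound 4 (0.09 log units; within the scatter), a 1.4-fold higher number from compound 3 to compound 4 (0.13 log units; within the scatter), and a 1.0-fold higher number from compound 1 to compound 4 (0.00 log units; within the scatter). Neither the change from a four-membered to a six-membered ring nor the move from oxan-2-yl to oxan-3-yl separates these four compounds on this read-out. No measurement at hand offers an explanation for this.

Going by these compounds, whether an amine, a carboxylic acid or a longer chain at this place would stay within the scatter remains open.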